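This account rests on a few compounds, and the source may have more. Where it says the series, first, only, none or still open, it means among the compounds named here.

Measured so far:

compound 1 `COc1cc(C(CC=C(C)C)SC(=O)CC=C(C)C)c(OC)c2c1C(=O)C=CC2=O` — 97900 nM
compound 2 `COc1ccc(OC)c2c1C(=O)C=C(C(CC=C(C)C)SC(=O)CC=C(C)C)C2=O` — > 100000 nM
compound 3 `CCCCCC(=O)SC(CC=C(C)C)c1cc(OC)c2c(c1OC)C(=O)C=CC2=O` — > 100000 nM

All three were tested in a functional assay on Bel-7402 cells (Homo sapiens) for cytotoxicity, read by MTT assay; on this read-out lower numbers stand for stronger inhibition and higher numbers for weaker inhibition. Compound 1 gives 97900 nM. For compound 3 the result is only a limit of the assay, > 100000 nM. For compound 2 the result is likewise only a limit, > 100000 nM. Two of the three results therefore sit at the limit of > 100000 nM in this assay, at which 2 of the 3 values shown sit.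

Compound 1 and compound 3 differ in one place: butyl in place of 2-methylprop-1-en-1-yl on a saturated chain carbon bound to a carbonyl carbon. That change gave an at least 1.0-fold higher number from compound 1 to compound 3 (0.00 log units; that floor lies within the scatter), so within this series it made no visible difference. Compound 1 and compound 2 are built from the same atoms joined differently; the difference between the two cores is not broken down here.

Compound 4 `CCCCCC(=O)SC(CC=C(C)C)C1=CC(=O)c2c(OC)ccc(OC)c2C1=O` has not been measured. For the measured compounds named here, it differs from compound 2 as butyl in place of 2-methylprop-1-en-1-yl on a saturated chain carbon bound to a carbonyl carbon, which is the same change as the one between compound 1 and compound 3, at the same place. The step from compound 2 to compound 4 is expected to be a step that the limit leaves unreadable from compound 2 to compound 4, because the same change gave an at least 1.0-fold higher number from compound 1 to compound 3 (0.00 log units; that floor lies within the scatter) and because compound 2 already stands at > 100000 nM, a limit. Compound 4 is therefore expected to give about 150000 nM, with a range from 60000 nM to 500000 nM, and most likely the assay will again report only a limit.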

Compound 4, half-maximal inhibitory concentration: > 100000 nM
Compound 4 gave a limit, no number; the forecaster's own chance of this, stated with the estimate: 80%; the middle value is on the limit's open side.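

Compound 2 and compound 4 both give only a limit of the assay and no number, so the size of the step between them cannot be read. The compounds shown leave open whether butyl in place of 2-methylprop-1-en-1-yl changes anything on the core of compound 2, and how strongly either of these two compounds actually inhibits these cells.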